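A few compounds are considered here, and "the series" means these few. Any claim that something is new, unique, unknown or untested is made for them only; others in the source may bear on it.

Values in a functional assay on MDA-MB-231 cells (Homo sapiens) for antiproliferative activity, read by MTT assay, with a stated time of 24 h; a higher number here means a weaker inhibitor, a lower number a stronger inhibitor:
Compound 1 `O=C(O)CC(NS(=O)(=O)c1ccc(F)cc1)c1ccccc1`: 88400 nM
Compound 2 `N#Cc1ccc(S(=O)(=O)NC(CC(=O)O)c2ccccc2)cc1`: 48700 nM

Compound 2 has only compound 1 as a neighbour on these numbers, and the two values lie within the scatter of each other. The next structure is compound 3 `O=C(O)CC(NS(=O)(=O)c1ccc(C(F)(F)F)cc1)c1ccccc1`, which carries trifluoromethyl in place of cyano on an aromatic carbon, para to a large group (trifluoromethyl in place of cyano on an aromatic carbon). Going by the values given here, one measured step bears on this change, a swap at the same carbon: a 1.8-fold lower number from compound 1 to compound 2 (0.26 log units; within the scatter). On that evidence, no step beyond the scatter is expected in this assay. The estimated step is a 1.1-fold higher number from compound 2 to compound 3 (0.05 log units; within the scatter). For compound 3 the expected value is 55000 nM, with an estimated range of 25000 nM to 120000 nM.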

Compound 3, half-maximal inhibitory concentration: 56100 nM
For compound 3 the middle estimate is 1.0-fold (0.01 log units) below the measured one; low and high end bracket the measured number.
By their numbers in this assay, from the lowest: compounds 2, 3 and 1 (each within the scatter of the next).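

In this assay the aromatic carbon para to a large group now carries a third group, and both new steps (a 1.2-fold higher number from compound 2 to compound 3 (0.06 log units; within the scatter); a 1.6-fold lower number from compound 1 to compound 3 (0.20 log units; within the scatter)) lie within the scatter. Fluoro, cyano and trifluoromethyl therefore stand as a set of three with no separation at this position, and trifluoromethyl, with 4 heavy atoms against 2 for cyano, opens no gap beyond the scatter. Nothing measured here accounts for why these numbers stay together.

Going by these compounds, how far this carbon can move the number remains unknown: an amine, a methoxy group or a longer alkyl chain there could still give a step beyond the scatter. On these data alone, the rest of the core, with its carboxylic acid, is the same in all three compounds, and the effect of a change there remains open.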